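A few compounds are considered here, and "the series" means these few. Any claim that something is new, unique, unknown or untested is made for them only; others in the source may bear on it.

Compound 1, `COC(=O)C(c1ccccc1)n1nnnc1[C@@H](COCc1ccccc1)NC(=O)C(C)(C)N`, gives 470 nM in an assay on isolated protein for displacement of a labelled ligand from growth hormone secretagogue receptor type 1 (Homo sapiens), with a stated time of 1 h; a lower number here means a stronger inhibitor, a higher number a weaker inhibitor.
Compound 2, `CC(C)(N)C(=O)N[C@H](COCc1ccccc1)c1nnnn1CCCCCNS(C)(=O)=O`, shows only the assay limit of > 5000 nM in this assay.

Compound 2 thus stands at the limit of > 5000 nM in this assay, at which 1 of the 2 values shown sits, with no number of its own. Compound 3, `CC(C)(N)C(=O)N[C@H](COCc1ccccc1)c1nnnn1CCCCC#N`, differs from it by cyano in place of (methanesulfonamido)methyl on a saturated chain carbon, four bonds along the chain from an aromatic nitrogen. Within the data shown here, the only measured step, an at least 10-fold higher number from compound 1 to compound 2 (1.02 log units; beyond the scatter), concerns a different position and offers no direct reading on this exchange; it shows only that the chain-bearing compound 2 sits far from compound 1. Compound 3 is therefore expected to remain weak, with a number no higher from compound 2 to compound 3 (the limit leaves the size open) and an estimated 5000 nM, between 1500 nM and 20000 nM.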

Compound 3, inhibition constant: 3120 nM
Compound 3: middle estimate off by 1.6-fold (0.20 log units), on the high side; the measured number falls inside the stated range.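

In this assay, the exchange to cyano on the chain gives an at least 1.6-fold lower number from compound 2 to compound 3 (0.20 log units; that floor lies within the scatter), so it can be read only as a floor and not as a clear gain. Among these compounds, with 4-cyanobutyl on the aromatic nitrogen, the comparison gives a 6.6-fold higher number from compound 1 to compound 3 (0.82 log units; beyond the scatter), which for the first time puts a measured size on what a chain costs against the group carried by compound 1. On these data alone, whether an amine or a carboxylic acid at the chain end, or a longer chain, would bring the number closer to that of compound 1 remains open.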